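The source may report more compounds than this note shows. Statements on the series, on what has been measured and on what is new or still open speak of the compounds shown alone.

Compound 1 `COc1ccc(C(=O)/C=C/c2ccc([N+](=O)[O-])o2)cc1` was tested in a toxicity assay on Vero cells (Chlorocebus sabaeus) for cytotoxicity (on this read-out higher numbers stand for lower toxicity in this test and lower numbers for higher toxicity in this test), where compound 1 gives 571000 nM. Two related compounds offer a comparison: compound 2 `COc1cc(C(=O)/C=C/c2ccc([N+](=O)[O-])o2)cc(OC)c1OC` gives 384000 nM, and compound 3 `O=C(/C=C/c1ccc([N+](=O)[O-])o1)c1ccc(OCc2ccc(OC(F)(F)F)cc2)cc1` gives 335000 nM. Compound 1 sits at the upper end of these three numbers, yet its distances to compound 2 and to compound 3 both fall within the scatter, so the three show no real difference between them. Compound 4 `C=C(C)COc1ccc(C(=O)/C=C/c2ccc([N+](=O)[O-])o2)cc1` has not yet been measured. It differs from compound 1 by 1-methylethenyl in place of hydrogen on a saturated chain carbon bound to an oxygen on an aromatic ring. Because compound 3 carries a much larger group in place of the methyl of the methoxy and still gives 335000 nM, no step beyond the scatter is expected here, in either direction. Compound 4 is estimated at 450000 nM, within 200000 nM to 900000 nM. The expected step is a 1.3-fold lower number from compound 1 to compound 4 (0.10 log units; within the scatter).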

Compound 4, half-maximal cytotoxic concentration: 393000 nM
The estimate for compound 4 lay 1.1-fold (0.06 log units) above the measured number; low and high end bracket the measured number.
By their numbers in this assay, from the lowest: compounds 3, 2, 4 and 1 (each within the scatter of the next).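

Putting 1-methylethenyl in place of hydrogen on this saturated chain carbon bound to an oxygen on an aromatic ring gives a 1.5-fold lower number from compound 1 to compound 4 (0.16 log units; within the scatter) in this assay. This is the first pair shown that differs in one place, and it indicates that adding a double bond outside aromatic rings here leaves the read-out unchanged within the scatter. Nothing measured here offers an explanation for this.

On these data alone, whether an amine or a carboxylic acid at this place would also leave the number unchanged remains open.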